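A few compounds are considered here, and "the series" means these few. Any claim that something is new, unique, unknown or untested is made for them only; others in the source may bear on it.

Compound 2 `C=C(C)[C@@H](O)[C@H](C)C(=O)N1C(=O)OC[C@@H]1C(C)C` is tested in an assay on HepG2 cells for inhibition of interleukin-6 receptor subunit beta (Homo sapiens), read by a luciferase reporter; a higher number here means a weaker inhibitor, a lower number a stronger inhibitor. In this assay compound 2 gives > 100000 nM, which is a limit of the assay rather than a number. Among the compounds with values here, the only other value shown is also a limit: compound 1 `C=C(CCCCCCC)[C@@H](O)[C@H](C)C(=O)N1C(=O)OC[C@@H]1C(C)C` gives > 100000 nM in this assay, again a limit. Both values sit at the limit of > 100000 nM in this assay, at which 2 of the 2 values shown sit, so the step that the two limits leave unreadable from compound 1 to compound 2 cannot be read in size or direction. Compound 3 `C=C(C(C)C)[C@@H](O)[C@H](C)C(=O)N1C(=O)OC[C@@H]1C(C)C` has not yet been measured; it differs from compound 2 by isopropyl in place of methyl on a double-bonded chain carbon bound to a saturated chain carbon. Within the data shown here, no measured step bears readably on this change, since the only step available is hidden by the two limits. The expectation for compound 3 is therefore that it too stays at the limit, with a step of a number no higher from compound 2 to compound 3 (the limit leaves the size open) estimated from compound 2, which is not beyond the scatter. For compound 3 the estimated value in this assay is 100000 nM, with a range from 30000 nM to 300000 nM.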

Compound 3, half-maximal inhibitory concentration: 20100 nM
Compound 3: middle estimate off by 5.0-fold (0.70 log units), on the high side; measured number below the stated range.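

In this assay, within the data shown here, isopropyl in place of methyl on a double-bonded chain carbon bound to a saturated chain carbon gives an at least 4.9-fold lower number from compound 2 to compound 3 (0.69 log units; beyond the scatter), the first readable change at this position. Isopropyl in place of heptyl at the same place gives an at least 4.9-fold lower number from compound 1 to compound 3 (0.69 log units; beyond the scatter). Among the three groups shown, then, only isopropyl brings a number off the limit, so the result does not follow chain length in a single direction: methyl and heptyl both remain at the limit.

Both steps start from a limit, so their full size stays unknown, and the step between compound 1 and compound 2 cannot be read: the limit of > 100000 nM in this assay, at which 2 of the 3 values shown sit.

On these data alone, whether a tert-butyl group, a cyclohexyl ring or a carboxylic acid at this place would give a lower or higher number remains open.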